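Reversed amide, saturated ring: expectation for compound 4

The compounds below may be only part of what the source reports. "The series", "measured", "known", "first", "only" and "open" are said of these compounds alone.

In an assay on CHO-K1 cells for displacement of a labelled ligand from prostaglandin E2 receptor EP1 subtype (Homo sapiens) (a lower number here means a stronger inhibitor, a higher number a weaker inhibitor), compound 1 `CNC(=O)c1cc(C)n(Cc2cc(Cl)ccc2OCc2ccccc2)n1` gives 100 nM, compound 2 `Cc1cc(C(=O)Nc2ccccc2)nn1Cc1cc(Cl)ccc1OCc1ccccc1` gives 39.8 nM, and compound 3 `Cc1cc(C(=O)NCc2ccncc2)nn1Cc1cc(Cl)ccc1OCc1ccccc1` gives 79.4 nM. Compound 3 thus stands second highest of the three numbers, nearest to compound 1 and furthest from compound 2. The measured steps all vary the group on the amide nitrogen: a 2.5-fold lower number from compound 1 to compound 2 (0.40 log units; beyond the scatter), a 1.3-fold lower number from compound 1 to compound 3 (0.10 log units; within the scatter), and a 2.0-fold higher number from compound 2 to compound 3 (0.30 log units; within the scatter). Compound 4 `Cc1cc(NC(=O)CC2CCCCC2)nn1Cc1cc(Cl)ccc1OCc1ccccc1` differs from compound 3 in that (((cyclohexylmethyl)carbonyl)amino in place of ((pyridin-4-yl)methyl)carbamoyl on an aromatic carbon). Among the measured compounds shown here, this turns the amide around and exchanges an aromatic ring for a saturated one, a change no measured step covers directly. The measured steps were all small, and a small step is expected in this assay, a 1.3-fold higher number from compound 3 to compound 4 (0.10 log units; within the scatter). Compound 4 is therefore estimated at 100 nM, expected to fall between 25 nM and 400 nM.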

Compound 4, half-maximal inhibitory concentration: 6.31 nM
Compound 4: middle estimate off by 16-fold (1.20 log units), on the high side; the measured number lies below the stated range.
By their numbers in this assay, from the lowest: compound 4; then compounds 2, 3 and 1 (each within the scatter of the next, the first and the last beyond it).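

Placing ((cyclohexylmethyl)carbonyl)amino on this aromatic carbon in this assay gives a 13-fold lower number from compound 3 to compound 4 (1.10 log units; beyond the scatter), a 6.3-fold lower number from compound 2 to compound 4 (0.80 log units; beyond the scatter) and a 16-fold lower number from compound 1 to compound 4 (1.20 log units; beyond the scatter). No change among the carbamoyl groups moved the number this far, so the reversed amide bearing a saturated carbon ring matters more at this position than those earlier swaps did. Nothing measured here explains the drop.

Compound 4 changes the amide's direction and the ring together, so the compounds shown cannot divide the effect between them. A reversed amide carrying phenylmethyl in place of cyclohexylmethyl would help separate the two.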